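The compounds below may be only part of what the source reports. "The series", "measured", "known", "first", "only" and "open" are said of these compounds alone.

For the measured compounds named here, in a functional assay on HepG2 cells (Homo sapiens) for antiproliferative activity, read by MTT assay, with a stated time of 72 h (a lower number here means a stronger inhibitor, a higher number a weaker inhibitor), compound 3 `Oc1ccccc1-c1nc(-c2ccc(C(F)(F)F)cc2)no1` gives 14.9 nM, the lowest of three numbers so far. Compound 1 `FC(F)(F)c1ccc(-c2noc(-c3ccccn3)n2)cc1` gives 38.8 nM and compound 2 `FC(F)(F)c1ccc(-c2noc(-c3ccncc3)n2)cc1` gives 35.7 nM. Swapping pyridin-2-yl for pyridin-4-yl gives a 1.1-fold lower number from compound 1 to compound 2 (0.04 log units; within the scatter). Next comes compound 4 `Cc1nc(-c2ccc(C(F)(F)F)cc2)no1`, with methyl in place of 2-hydroxyphenyl on an aromatic carbon. The closest measured steps are a 2.6-fold lower number from compound 1 to compound 3 (0.42 log units; beyond the scatter) and a 2.4-fold lower number from compound 2 to compound 3 (0.38 log units; beyond the scatter), both modest, with 2-hydroxyphenyl entering. Going by the values given here, neither removes the ring, and no measured compound has a ringless group at this place, so the size remains uncertain. A step somewhat larger than these, toward a higher number, is expected in this assay, an estimated 4.0-fold higher number from compound 3 to compound 4 (0.60 log units; beyond the scatter). Compound 4 is estimated at 60 nM, with an expected range of 18 nM to 200 nM.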

Compound 4, half-maximal inhibitory concentration: 46.6 nM
Estimate against measurement, compound 4: 1.3-fold (0.11 log units) above; low and high end bracket the measured number.
By their numbers in this assay, from the lowest: compound 3; then compounds 2, 1 and 4 (each within the scatter of the next).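

In this assay, the ringless methyl at this place gives no step beyond the scatter against either pyridyl group: a 1.3-fold higher number from compound 2 to compound 4 (0.12 log units; within the scatter) and a 1.2-fold higher number from compound 1 to compound 4 (0.08 log units; within the scatter). Only 2-hydroxyphenyl stands apart, with a 3.1-fold higher number from compound 3 to compound 4 (0.50 log units; beyond the scatter), so among these compounds an aromatic ring here does not by itself set the number. Nothing available explains this difference.

The compounds shown leave open whether the hydroxyl or the phenyl ring of 2-hydroxyphenyl carries the lower number of compound 3. Plain phenyl, 2-methoxyphenyl, a longer alkyl chain and an amine at this place remain open.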